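The source may report more compounds than this note shows. Statements on the series, on what has been measured and on what is new or still open speak of the compounds shown alone.

Compound 1 `Cc1ccc2c(c1)-c1cnc(n1C)OCCCCCCCCO2` and compound 2 `COc1ccc2c(c1)-c1cnc(n1C)OCCCCCCCCO2` share one core, while compound 3 `C=CCCCCOc1ccc(C)cc1-c1cnc(OCCC=C)n1C` is built on a different core. In a functional assay on PC-3 cells (Homo sapiens) for inhibition, read by colorimetric assay and MTT assay, with a stated time of 72 h (a higher number here means a weaker inhibitor, a lower number a stronger inhibitor), compound 1 gives 36000 nM, compound 2 gives 40000 nM, and compound 3 gives 59000 nM. The move from compound 1 to compound 2 is methoxy in place of methyl on an aromatic carbon and it made a 1.1-fold higher number from compound 1 to compound 2 (0.05 log units; within the scatter). How the core of compound 3 differs from the core of compound 1 is not broken down here. Compound 4 `C=CCCCCOc1ccc(OC)cc1-c1cnc(OCCC=C)n1C` arises from compound 3 by methoxy in place of methyl on an aromatic carbon, the same kind of change, but here the ring is not part of a fused or bridged system of three rings, and the carbon stands meta to a large group and para to a (hex-5-en-1-yl)oxy group rather than meta and para to a fused ring. Because that change made a 1.1-fold higher number from compound 1 to compound 2 (0.05 log units; within the scatter), compound 4 is expected to move only by a 1.1-fold higher number from compound 3 to compound 4 (0.04 log units; within the scatter). The estimate for compound 4 in this assay is 65000 nM, expected to fall between 30000 nM and 140000 nM.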

Compound 4, half-maximal inhibitory concentration: 43000 nM
For compound 4 the middle estimate is 1.5-fold (0.18 log units) above the measured one; the range from low to high includes it.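

In this assay methoxy in place of methyl on an aromatic carbon made a 1.4-fold lower number from compound 3 to compound 4 (0.14 log units; within the scatter) on the second core. Set beside the same change on the shared core of compound 1 and compound 2, the two steps do not differ: the same change on two cores in this assay, a 1.1-fold higher number (0.05 log units; within the scatter) from compound 1 to compound 2 and a 1.4-fold lower number (0.14 log units; within the scatter) from compound 3 to compound 4, 1.5-fold (0.18 log units) apart, within the scatter of two such steps. This shows that, across these two pairs, the change stayed within the scatter on both cores, so the small step seen on one core held on the other; it does not show that the change would behave the same way on any further core, and two such small steps give no direction for it.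

The compounds shown leave open whether an amine or a carboxylic acid on that aromatic carbon would give a step beyond the scatter on either core. They also leave open what a longer chain in place of the (hex-5-en-1-yl)oxy group would do to the number in this assay.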